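Chloro in place of amino on the aryl group

A few compounds are considered here, and "the series" means these few. Any claim that something is new, unique, unknown or untested is made for them only; others in the source may bear on it.

Measured so far:
compound 1 `Fc1ccc2c(c1)CCC(c1nnc(-c3cn(Cc4c(F)cccc4F)nn3)o1)O2`: 88000 nM
compound 2 `O=c1cc(-c2nnc(C3CCc4cc(F)ccc4O3)o2)oc2ccc(F)cc12`: 73900 nM
compound 3 `Nc1ccc(-c2nnc(C3CCc4cc(F)ccc4O3)o2)cc1`: 89100 nM

Of the compounds shown here, three sharing the same core have been tested in a functional assay; on this read-out lower numbers stand for stronger inhibition and higher numbers for weaker inhibition. Compound 1 gives 88000 nM in this assay, compound 2 gives 73900 nM, and compound 3 gives 89100 nM. Compound 3 stands among the other two rather than apart from them: its number differs from those of compound 1 and compound 2 by amounts that sit within the usual scatter of this assay, so none of the three can be set apart from the others. All three give weak inhibition in this assay.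

Compound 4 `Fc1ccc2c(c1)CCC(c1nnc(-c3ccc(Cl)cc3)o1)O2` has not yet been measured. It differs from compound 3 in one place: chloro in place of amino on an aromatic carbon, para to a large group. For the measured compounds named here, no step between two measured compounds changes one place only, so there is no measured pair to lean on. Since the varied aryl groups of compounds 1, 2 and 3 all land close together in this assay, the expectation for compound 4 is a step of a 1.1-fold lower number from compound 3 to compound 4 (0.05 log units; within the scatter), a change not beyond the scatter. Compound 4 is therefore estimated at 80000 nM in this assay, with a range from 25000 nM to 250000 nM.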

Compound 4, half-maximal inhibitory concentration: 85900 nM
Beside the measured number, compound 4's estimate is 1.1-fold (0.03 log units) below it; measured number inside the range.
By their numbers in this assay, from the lowest: compounds 2, 4, 1 and 3 (each within the scatter of the next).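

For the compounds shown here, this is the first comparison that changes one place only, and in this assay putting chloro in place of amino on the aromatic carbon gives a 1.0-fold lower number from compound 3 to compound 4 (0.02 log units; within the scatter), so the two compounds cannot be told apart. At this position, the 4-aminophenyl group, with its hydrogen-bond donor and acceptor, and the 4-chlorophenyl group, with neither, therefore read the same, and compound 4 at 85900 nM still shows only weak inhibition. No measurement at hand bears on why this exchange leaves the two compounds indistinguishable.

As far as these compounds go, a single pair cannot show whether this position tolerates every group, and it remains open whether a carboxylic acid, a dimethylamino group or a longer chain in the same place would move the number beyond the scatter. From the compounds shown here alone, it is equally open whether any exchange on the aryl group can yield stronger inhibition while the shared core stays as it is, or whether a change to the core itself, such as an amine in place of its fluoro group, would be needed first.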